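The source may hold more compounds than are shown below. What is called first, only, known or untested is meant among the compounds shown, and "the series" means these compounds.

Compound 2, `CCOc1ccccc1-c1ccc(-c2nc3cnccc3c(N[C@H](CC(C)C)C(N)=O)c2C#N)cc1`, sits at the top of the two measured values: in a physicochemical assay for lipophilicity, read by HPLC, at pH 7.5 (on this read-out lower numbers stand for lower lipophilicity and higher numbers for higher lipophilicity), compound 2 gives 3.4, whereas compound 1, `CC(C)(CC(N)=O)c1c(C#N)c(-c2ccc(Br)cc2)nc2cnccc12`, gives in this assay 2.1, a gap that lies beyond the usual scatter. Compound 3, `CCOc1ccccc1-c1ccc(-c2nc3cnccc3c(N[C@H](CC)C(=O)N(C)C)c2C#N)cc1`, is built from the same atoms as compound 2, joined differently (1-(dimethylcarbamoyl)propyl in place of 1-carbamoyl-3-methylbutyl on a nitrogen on an aromatic ring). Going by the values given here, no step between two measured compounds of this kind has been recorded, so the expectation rests on the change itself: the side chain shortens while the amide nitrogen carries two methyls and loses its hydrogen-bond donor, and these two parts of the change are expected to pull in opposite directions and roughly cancel. The expected step in this assay a number 0.10 log units higher from compound 2 to compound 3 (within the scatter) is therefore small and within the scatter. Compound 3 is estimated to give 3.5 in this assay, expected to fall between 3 and 4.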

Compound 3, distribution coefficient: 3.7
Compound 3: the middle estimate sits 0.20 log units below what was measured; the measured number falls inside the stated range.
By their numbers in this assay, from the lowest: compound 1; then compounds 2 and 3 (each within the scatter of the next).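

At this place, on a nitrogen on an aromatic ring, putting 1-(dimethylcarbamoyl)propyl in place of 1-carbamoyl-3-methylbutyl gives in this assay a step of a number 0.30 log units higher from compound 2 to compound 3 (within the scatter) and so leaves the read-out unresolved between these two side chains. Going by these compounds alone, the exchange goes from 1 hydrogen-bond donor to 0 hydrogen-bond donors and also alters the chain, yet the single step shows no separate effect of either part. Nothing measured here accounts for the size of this step.

The compounds shown leave open what each part of the exchange contributes alone, which a 1-carbamoylpropyl group at this nitrogen could begin to separate. They also leave open how this assay would respond to a side chain ending in a carboxylic acid or an amine at this place.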